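Ring size at the triazole carbon: from cyclopropyl to cyclohexyl

The compounds below may be only part of what the source reports. "The series", "measured", "known", "first", "only" and "open" are said of these compounds alone.

The three measured compounds and their numbers in a functional assay on NCI-H226 cells (Homo sapiens) for inhibition, read by MTT assay, with a stated time of 72 h; a higher number here means a weaker inhibitor of growth, a lower number a stronger inhibitor of growth:
Compound 1, `COC(=O)c1nc(C)n(-c2ccc(F)cc2)n1`, gives 11700 nM.
Compound 2, `CCc1nc(C(=O)OC)nn1-c1ccc(F)cc1`, gives 71300 nM.
Compound 3, `COC(=O)c1nc(C2CC2)n(-c2ccc(F)cc2)n1`, gives 16300 nM.

Compound 3 stands second highest of the three in this assay; its nearest neighbour is compound 1, with a 1.4-fold higher number from compound 1 to compound 3 (0.14 log units; within the scatter), and its furthest is compound 2, with a 4.4-fold lower number from compound 2 to compound 3 (0.64 log units; beyond the scatter). Compound 4, `COC(=O)c1nc(C2CCCCC2)n(-c2ccc(F)cc2)n1`, differs from compound 3 by cyclohexyl in place of cyclopropyl on an aromatic carbon.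

Among the measured compounds shown here, two measured steps bear on this change. Replacing methyl with cyclopropyl on that aromatic carbon left the number essentially unchanged, since a 1.4-fold higher number from compound 1 to compound 3 (0.14 log units; within the scatter) lies within the scatter. For the measured compounds named here, replacing methyl with ethyl, however, gave a 6.1-fold higher number from compound 1 to compound 2 (0.78 log units; beyond the scatter), a step beyond the scatter, and the ethyl compound is also the one that compound 3 improves upon with a 4.4-fold lower number from compound 2 to compound 3 (0.64 log units; beyond the scatter). Going by the values given here, the one enlargement of the group on this carbon that was measured therefore raised the number, while cyclopropyl was tolerated. Cyclohexyl is a further enlargement, from a three-membered to a six-membered ring, for which no direct precedent exists among these compounds.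

Compound 4 is therefore expected to give a higher number than compound 3, with an estimated step of a 2.8-fold higher number from compound 3 to compound 4 (0.44 log units; beyond the scatter). The estimate for compound 4 in this assay is 45000 nM, with a range from 12000 nM to 160000 nM.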

Compound 4, concentration for 50% growth inhibition: 6260 nM
For compound 4 the middle estimate is 7.2-fold (0.86 log units) above the measured one; the whole stated range lies above it.
By their numbers in this assay, from the lowest: compounds 4, 1 and 3 (each within the scatter of the next, the first and the last beyond it); then compound 2.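

In this assay, cyclohexyl, the largest group seen on this aromatic carbon, does not raise the number: the change from cyclopropyl gives a 2.6-fold lower number from compound 3 to compound 4 (0.42 log units; beyond the scatter), and the change from ethyl gives an 11-fold lower number from compound 2 to compound 4 (1.06 log units; beyond the scatter). The change from methyl gives a 1.9-fold lower number from compound 1 to compound 4 (0.27 log units; within the scatter), so these two cannot be told apart, and the number does not simply follow the size of the group, with the ethyl of compound 2 going against any such trend. Nothing available explains why the ethyl compound stands apart from the compounds with cyclopropyl and cyclohexyl.

The compounds shown leave open whether cyclobutyl or cyclopentyl would fall in line with the two rings seen here. They also leave open whether a longer chain such as propyl or butyl would behave like ethyl, and how a phenyl ring would fare at this position.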